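The source may report more compounds than this note shows. Statements on the series, on what has been measured and on what is new or still open speak of the compounds shown alone.

Measured so far:
compound 1 `ClCc1ccccc1Cn1cnc2ncnc(Cl)c21`: 11200 nM
compound 2 `ClCc1ccc(Cn2cnc3c(Cl)nc(Cl)nc32)cc1`: 2190 nM

Compound 1 gives 11200 nM in a functional assay on HOP-62 cells (Homo sapiens) for cytotoxicity, read by sulforhodamine B assay, with a stated time of 48 h (a lower number here means a stronger inhibitor of growth, a higher number a weaker inhibitor of growth), the highest of the two numbers. Among the measured compounds shown here, compound 2 gives 2190 nM in this assay, a lower number, and the gap between the two lies beyond the scatter; since the two differ in more than one place, no single step connects them and the values stand only side by side.

Compound 3 `ClCc1ccccc1Cn1cnc2nc(Cl)nc(Cl)c21` is not yet measured. It differs from compound 1 by chloro in place of hydrogen on an aromatic carbon of the shared core. For the measured compounds named here, no measured pair shows this change alone, so its size is uncertain. Because compound 2, whose core carries two chloro groups, gives 2190 nM, a move toward a lower number is expected, of moderate size. Compound 3 is expected to give 4000 nM in this assay, within 1500 nM to 12000 nM. The expected step is a 2.8-fold lower number from compound 1 to compound 3 (0.45 log units; beyond the scatter).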

Compound 3, concentration for 50% growth inhibition: 2690 nM
Beside the measured number, compound 3's estimate is 1.5-fold (0.17 log units) above it, and the stated range covers the measured number.
By their numbers in this assay, from the lowest: compounds 2 and 3 (each within the scatter of the next); then compound 1.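

In this assay, among the compounds shown here, the change of chloro in place of hydrogen on an aromatic carbon, between two ring nitrogen atoms, can now be read alone: it gives a 4.2-fold lower number from compound 1 to compound 3 (0.62 log units; beyond the scatter) and so forms the first single-change pair. This position of the shared core therefore responds to substitution, with a step beyond the scatter, though the reading rests on a single pair and a single group. No measurement at hand explains the size or direction of this step.

From the compounds shown here alone, whether an amine, a methoxy group or a fluoro group at this position would move the number in the same direction remains open. Also open, going by these compounds, is how the step would change if the chloro group already on the core of compound 1 gave way to an amine.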